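Pyrrolidinylpyridine in place of sulfamoylphenyl on the thiazole acid core

The compounds below may be only part of what the source reports. "The series", "measured", "known", "first", "only" and "open" are said of these compounds alone.

The study concerns antagonists of the prostaglandin D2 receptor, tested in an in vitro functional assay on HEK285-7 cells for antagonist activity at prostaglandin D2 receptor 2 (Homo sapiens), read by BRET and beta-arrestin recruitment; on this read-out higher numbers stand for weaker inhibition and lower numbers for stronger inhibition. Compound 1 `O=C(O)Cc1sc(C(c2ccccc2)c2ccc(F)c(F)c2)nc1-c1ccc(F)cc1` gives 64 nM in this assay. Compound 2 `NS(=O)(=O)c1ccc(-c2nc(C(c3ccc(F)cc3)c3ccc(F)cc3)sc2CC(=O)O)cc1` carries a 4-sulfamoylphenyl group and two 4-fluorophenyl groups; in this assay compound 2 reaches only > 100000 nM, which is a limit of the assay and not a number. Compound 2 thus stands at the limit of > 100000 nM in this assay, at which 1 of the 2 values shown sits, the weakest position the data allow.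

Compound 3 `O=C(O)Cc1sc(C(c2ccc(F)cc2)c2ccc(F)cc2)nc1-c1ccnc(N2CCCC2)c1` has not yet been measured. It differs from compound 2 in one place: 2-(pyrrolidin-1-yl)pyridin-4-yl in place of 4-sulfamoylphenyl on an aromatic carbon. Within the data shown here, no measured pair shows this exact exchange, so its size is open. Given that compound 1, with a small aromatic group at the same position, gives 64 nM, a gain in inhibition is expected for compound 3, estimated at 500 nM (range 50 nM to 10000 nM), corresponding to the expected step of an at least 200-fold lower number from compound 2 to compound 3 (2.30 log units; beyond the scatter).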

Compound 3, half-maximal inhibitory concentration: > 100000 nM
Compound 3 was reported as a limit; the forecaster's own chance of this, stated with the estimate: 20%; at least 200-fold (2.30 log units) between middle value and limit.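

Compound 2 and compound 3 are both reported only as limits in this assay, not as numbers, so no step between them can be read: the limit of > 100000 nM in this assay, at which 2 of the 3 values shown sit.

The compounds shown leave open how 2-(pyrrolidin-1-yl)pyridin-4-yl and 4-sulfamoylphenyl compare on the shared core in this assay.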